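The source may report more compounds than this note shows. Statements on the series, on what has been measured and on what is new or still open speak of the compounds shown alone.

Compound 1 `Oc1ccc(O)c(-c2cc(-c3ccc(Cl)cc3)nn2-c2ccccc2)c1` gives 32500 nM in a functional assay on cells (Melanoma cell, Homo sapiens) for cytotoxicity, read by sulforhodamine B assay, with a stated time of 48 h; on this read-out higher numbers stand for weaker inhibition of growth and lower numbers for stronger inhibition of growth. Compound 2 `NS(=O)(=O)c1ccc(-n2nc(-c3ccc(Cl)cc3)cc2-c2cc(O)ccc2O)cc1` gives 38900 nM in this assay.

Compound 1 has the lowest of the two numbers, and its neighbour is compound 2, with a 1.2-fold higher number from compound 1 to compound 2 (0.08 log units; within the scatter). Compound 3 `O=C1C=CC(=O)C(c2cc(-c3ccc(Cl)cc3)nn2-c2ccccc2)=C1` differs from compound 1 by a group of 8 heavy atoms (6 carbon, 2 oxygen; one six-membered non-aromatic ring of carbon only) in place of a group of 8 heavy atoms (6 carbon, 2 oxygen; one six-membered aromatic ring of carbon only), on an aromatic carbon. Within the data shown here, the one measured step, from compound 1 to compound 2, alters a different part of the shared core and does not bear on this change, so no measured step informs the expectation. Compound 3 is therefore expected to lie close to compound 1, with a broad range, at 20000 nM (from 4000 nM to 80000 nM), a step of a 1.6-fold lower number from compound 1 to compound 3 (0.21 log units; within the scatter).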

Compound 3, concentration for total growth inhibition: 55400 nM
For compound 3 the middle estimate is 2.8-fold (0.44 log units) below the measured one; low and high end bracket the measured number.
By their numbers in this assay, from the lowest: compounds 1, 2 and 3 (each within the scatter of the next).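

In this assay this position tolerates the exchange: replacing the 2,5-dihydroxyphenyl group with a non-aromatic ring of carbon only, which has 0 hydrogen-bond donors, gives a 1.7-fold higher number from compound 1 to compound 3 (0.23 log units; within the scatter). Among the compounds shown, neither the aromatic ring nor the hydrogen-bond donors of this group are needed to keep the number within the scatter. Nothing measured here accounts for this result. The compounds shown leave open how a 2,5-dimethoxyphenyl group or an unsubstituted phenyl group would read at this position. They also leave open whether the sulfamoyl group would leave the number of compound 3 as little changed as it does that of compound 1.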